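Replacing the halophenyl of compound 3 with a furanyl

A few compounds are considered here, and "the series" means these few. Any claim that something is new, unique, unknown or untested is made for them only; others in the source may bear on it.

Compound 1 `CCOC(=O)C12C(=O)OCC=C1COC2c1ccc(F)cc1` in a functional assay on QGY cells (Homo sapiens) for cytotoxicity, read by MTT assay; on this read-out lower numbers stand for stronger inhibition and higher numbers for weaker inhibition: > 1000000 nM, which is a limit of the assay.
Compound 2 `CCOC(=O)C12C(=O)OCC=C1COC2c1ccc(Cl)cc1` in this assay: > 1000000 nM, a limit.
Compound 3 `CCOC(=O)C12C(=O)OCC=C1COC2c1ccc(Br)cc1` in this assay: > 1000000 nM, a limit.

Compound 3 therefore stands at the limit, as do the two other measured compounds (the limit of > 1000000 nM in this assay, at which 3 of the 3 values shown sit). Within the data shown here, the steps a step that the two limits leave unreadable from compound 1 to compound 2, a step that the two limits leave unreadable from compound 1 to compound 3 and a step that the two limits leave unreadable from compound 2 to compound 3 cannot be sized, so no measured step bears readably on the change to compound 4 `CCOC(=O)C12C(=O)OCC=C1COC2c1ccco1`, which is furan-2-yl in place of 4-bromophenyl on a saturated ring carbon. With every value shown sitting at the limit, compound 4 is expected to remain there too, so the step of a number no higher from compound 3 to compound 4 (the limit leaves the size open) is estimated to be none beyond the scatter. Compound 4 is thus estimated at 1000000 nM in this assay, within 300000 nM to 3000000 nM.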

Compound 4, half-maximal inhibitory concentration: > 1000000 nM
Compound 4: a limit, no number; the forecaster's own chance of this, stated with the estimate: 85%; the middle value lies on the limit itself.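

In this assay, among these compounds, compound 1, compound 2, compound 3 and compound 4 all stand at a limit, so no step to compound 4 can be read. The compounds shown leave open whether the group on the saturated ring carbon affects cytotoxicity at all.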